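A few compounds are considered here, and "the series" means these few. Any claim that something is new, unique, unknown or untested is made for them only; others in the source may bear on it.

Working notes on the oxime-ether acid series in a functional assay on the whole organism for inhibition, with Rattus norvegicus as the target, read by paw edema, with stated times of 1 h and 3 h, at a dose of 50 mg/kg by the oral route; on this read-out higher numbers stand for more inhibition at the one dose given (going by the name of the read-out) and lower numbers for less inhibition. The core of compound 1 `C/C(=N\OCC(=O)O)c1ccccc1` is the reference point. In this assay compound 1 gives < 20%, which is a limit of the assay and not a number. Compound 2 `C/C(=N\OCC(=O)O)c1ccc(CC2CCCCC2)cc1` carries cyclohexylmethyl in place of hydrogen on an aromatic carbon; in this assay compound 2 gives < 20%, again only a limit. Compound 3 `COc1ccc(/C(C)=N/OCC(=O)O)cc1` carries methoxy in place of hydrogen on an aromatic carbon; in this assay compound 3 gives < 20%, also a limit. The three steps measured so far are consequently not readable: a step that the two limits leave unreadable from compound 1 to compound 2, a step that the two limits leave unreadable from compound 1 to compound 3 and a step that the two limits leave unreadable from compound 2 to compound 3. Nothing on direction or size can be drawn from them because of the limit of < 20% in this assay, at which 3 of the 3 values shown sit.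

Compound 4 `C/C(=N\OCC(=O)O)c1ccc([N+](=O)[O-])cc1` remains to be measured. It differs from compound 1 by nitro in place of hydrogen on an aromatic carbon, the nitro sitting on an aromatic carbon of a six-membered aromatic ring of carbon only, para to a group of 8 heavy atoms. For the measured compounds named here, none of the measured steps covers this particular change. The step that the limit leaves unreadable from compound 1 to compound 4 is expected to stay within the scatter, the reason being (the limit of < 20% in this assay, at which 3 of the 3 values shown sit). Compound 4 is therefore expected to give about 15% in this assay, within a range of 0% to 35%, most probably reported again as a limit.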

Compound 4, a percentage reported as inhibition, in the whole organism at one dose (the size of the read-out at that dose, not a potency): < 20%
Compound 4 was reported as a limit; the forecaster's own chance of this, stated with the estimate: 70%; the middle value lies beyond the limit too.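

In this assay compound 4 gives < 20%, a limit of the assay and not a number. The steps joining compound 4 to compound 1, compound 2 and compound 3 therefore cannot be read: the limit of < 20% in this assay, at which 4 of the 4 values shown sit.

Left open is whether nitro, methoxy or cyclohexylmethyl in place of hydrogen on an aromatic carbon changes the inhibition at all, and in which direction.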